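From Bromophenyl to Nitrophenyl: Where the Lipophilicity Goes

The source may hold more compounds than are shown below. What is called first, only, known or untested is meant among the compounds shown, and "the series" means these compounds.

Two compounds from this study share a steroid-like core and have been measured in a physicochemical assay for lipophilicity; a higher number here means a more lipophilic compound, a lower number a more polar compound. Compound 1 (`COc1ccc(C2=NO[C@]3(C2)C(=O)O[C@@H]2[C@H]3CC[C@H](C)[C@]3(O)C=CC(=O)[C@@]23C)cc1`) gives 1.47 in this assay. Compound 2 (`C[C@H]1CC[C@@H]2[C@@H](OC(=O)[C@]23CC(c2ccc(Br)cc2)N(c2ccccc2)O3)[C@]2(C)C(=O)C=C[C@@]12O`) gives 4 in this assay, the higher of the two numbers, and the gap to compound 1 lies well beyond the usual scatter of such measurements. The two compounds differ in more than one place, so their values are simply two points and not a single step.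

The next compound, compound 3 (`C[C@H]1CC[C@@H]2[C@@H](OC(=O)[C@]23CC(c2ccc([N+](=O)[O-])cc2)N(c2ccccc2)O3)[C@]2(C)C(=O)C=C[C@@]12O`), is built from compound 2 by one change: nitro in place of bromo on an aromatic carbon. Cut one bond further out, this reads 4-bromophenyl to 4-nitrophenyl.

Going by the values given here, no measured pair in this set isolates this change, so the expectation rests on the value of compound 2 and the nature of the swap. The step from compound 2 to compound 3 in this assay is expected to be a number 1.10 log units lower from compound 2 to compound 3 (beyond the scatter), a clear drop beyond the scatter. On that basis compound 3 is estimated to give 2.9 in this assay, within a range from 2.4 to 3.5.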

Compound 3, partition coefficient: 3.15
The estimate for compound 3 lay 0.25 log units below the measured number; measured number inside the range.
By their numbers in this assay, from the lowest: compound 1; then compound 3; then compound 2.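

Going by these compounds alone, the swap of bromo for nitro on this aromatic carbon, para to a large group, is the first change in the set that can be read alone: in this assay it gives a number 0.85 log units lower from compound 2 to compound 3 (beyond the scatter). The gap between the first two compounds could not be tied to any one part of their structures, whereas here everything else stays fixed, so this position clearly registers in the measurement and the step belongs to this one exchange. The counts show that bromo carries no hydrogen-bond acceptors and nitro carries two, but no measurement here links that difference, or any other feature of the two groups, to the step, so the data offer no explanation for it.

A single step cannot show whether other groups on this carbon, such as an amine, a carboxylic acid or a longer chain, would lower the number further or raise it again. It also leaves open whether the same nitro-for-bromo exchange would give a step of similar size on the aromatic ring of compound 1, where the surroundings differ.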